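One Chloro Fewer: From Compound 3 to Compound 4

The source may hold more compounds than are shown below. What is called first, only, known or untested is meant among the compounds shown, and "the series" means these compounds.

Of the compounds shown here, three have been measured in a functional assay on KM12 cells (Homo sapiens) for cytotoxicity, read by sulforhodamine B assay, with a stated time of 48 h; on this read-out higher numbers stand for weaker inhibition of growth and lower numbers for stronger inhibition of growth. Compound 1 `Nc1nc(Cl)c2ncn(Cc3ccccc3CCl)c2n1` gives 15500 nM. Compound 2 `ClCc1cccc(Cn2cnc3nc(Cl)nc(Cl)c32)c1` gives 16600 nM in this assay. Compound 3 `ClCc1ccccc1Cn1cnc2nc(Cl)nc(Cl)c21` gives 11700 nM, the lowest of the three numbers, yet its gap to compound 1 and its gap to compound 2 both fall within the usual scatter of repeated measurements, so the three compounds cannot be told apart on these numbers.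

Compound 4 `ClCc1ccccc1Cn1cnc2ncnc(Cl)c21` has not yet been measured. It differs from compound 3 in one place: hydrogen in place of chloro on an aromatic carbon. Within the data shown here, no pair of measured compounds shows how such a change plays out here, so the expectation rests on the three close-lying numbers alone. In this assay the step from compound 3 to compound 4 is expected to be small, not clearly beyond the scatter, and is estimated as a 1.3-fold higher number from compound 3 to compound 4 (0.11 log units; within the scatter). Compound 4 is therefore expected to give about 15000 nM, with a range from 5000 nM to 45000 nM.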

Compound 4, concentration for 50% growth inhibition: 3630 nM
Compound 4: the middle estimate sits 4.1-fold (0.62 log units) above what was measured; measured number below the stated range.
By their numbers in this assay, from the lowest: compound 4; then compounds 3, 1 and 2 (each within the scatter of the next).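

The three earlier numbers could not be told apart, so they gave no sign that any one part of these structures mattered in this assay. Placing hydrogen instead of chloro on the aromatic carbon between two ring nitrogen atoms gives a clear change (a 3.2-fold lower number from compound 3 to compound 4 (0.51 log units; beyond the scatter)), which shows that growth inhibition responds to what sits at this position and that a chloro there is not needed for it. What lies behind the change cannot be said from the data at hand.

Going by these compounds, whether a methyl or a methoxy group at this position would give a lower or a higher number remains open. On these data alone, it is also open whether the same exchange of chloro for hydrogen would have a similar effect on compound 2, or whether it holds only for compound 3.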